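A few compounds are considered here, and "the series" means these few. Any claim that something is new, unique, unknown or untested is made for them only; others in the source may bear on it.

Within the data shown here, compound 2 `C=C1CC(c2ccccc2)N(C)C1=O` gives 989000 nM in a functional assay on HL-60 cells (Homo sapiens) for cytotoxicity, read by MTT assay, with a stated time of 48 h (on this read-out higher numbers stand for weaker inhibition and lower numbers for stronger inhibition), the only number recorded for it, and a very weak one. Compound 1 `C=C1C(=O)OC(c2ccc(OC)cc2)C1C`, built on a different core, gives 37900 nM; 5690 nM (2 entries) in this assay. Compound 3 `C=C1CC(c2ccc(OC)cc2)N(C)C1=O` differs from compound 2 by methoxy in place of hydrogen on an aromatic carbon. Among the measured compounds shown here, no measured pair in this set shows that change on its own, so the size of its effect here is unknown; the expectation is a small step of a 1.6-fold lower number from compound 2 to compound 3 (0.22 log units; within the scatter), not beyond the usual scatter. Compound 3 is therefore expected to give 600000 nM in this assay, within a range from 150000 nM to 2000000 nM.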

Compound 3, half-maximal inhibitory concentration: 611000 nM
Estimate against measurement, compound 3: 1.0-fold (0.01 log units) below; the measured number falls inside the stated range.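

Methoxy in place of hydrogen on an aromatic carbon, para to a group of 8 heavy atoms, now has a measured effect in this assay: a 1.6-fold lower number from compound 2 to compound 3 (0.21 log units; within the scatter). This change therefore leaves compound 3 about where compound 2 stands, and both remain very weak. A step of this size cannot be told apart from the spread of repeated readings, which can be wide here: the several entries of compound 1 in this assay, 37900 nM; 5690 nM (2 entries)

On these data alone, whether an amine or a carboxylic acid at this carbon would move the number beyond the scatter remains open. Also open, as far as these compounds go, is what the same change does on the core of compound 1, which appears here only with methoxy.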